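The source may report more compounds than this note shows. Statements on the series, on what has been measured and on what is new or still open speak of the compounds shown alone.

Measured so far in a functional assay on WM 266-4 cells (Homo sapiens) for antiproliferative activity, read by MTT assay, with a stated time of 48 h; on this read-out lower numbers stand for stronger inhibition and higher numbers for weaker inhibition:

Compound 1, `Cc1ccc(C2=NN(c3nc(-c4ccccc4)cs3)C(c3cccs3)C2)cc1`, gives 7520 nM.
Compound 2, `Cc1ccc(C2=NN(c3nc(-c4ccc(C(F)(F)F)cc4)cs3)C(c3cccs3)C2)cc1`, gives 2110 nM.
Compound 3, `Brc1ccc(C2=NN(c3nc(-c4ccccc4)cs3)C(c3cccs3)C2)cc1`, gives 1870 nM.

The three share one core and differ only in the groups on the two outer phenyl rings. From compound 1 to compound 2 the change is trifluoromethyl in place of hydrogen on an aromatic carbon, and the step in this assay is a 3.6-fold lower number from compound 1 to compound 2 (0.55 log units; beyond the scatter). From compound 1 to compound 3 the change is bromo in place of methyl on an aromatic carbon, giving a step of a 4.0-fold lower number from compound 1 to compound 3 (0.60 log units; beyond the scatter). Compound 2 and compound 3 lie within the scatter of each other, so no order between them is claimed. Compound 1 stands apart from both.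

Compound 4, `FC(F)(F)c1ccc(-c2csc(N3N=C(c4ccc(Br)cc4)CC3c3cccs3)n2)cc1`, is not yet measured. It differs from compound 3 by trifluoromethyl in place of hydrogen on an aromatic carbon. This is the same change already made from compound 1 to compound 2, on the same place of the same ring, while the two cores differ as described under the change from compound 1 to compound 3. Among the compounds shown this change occurs twice in all.

For compound 4 in this assay a step of a 2.9-fold lower number from compound 3 to compound 4 (0.46 log units; beyond the scatter) is expected, somewhat smaller than the one seen because a 3.6-fold lower number from compound 1 to compound 2 (0.55 log units; beyond the scatter) was measured on compound 1, which starts from a weaker point than compound 3 does at 1870 nM. The estimate for compound 4 is 650 nM, with a range from 250 nM to 1700 nM.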

Compound 4, half-maximal inhibitory concentration: 27400 nM
Compound 4: middle estimate off by 42-fold (1.62 log units), on the low side; measured number above the stated range.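

In this assay, trifluoromethyl in place of hydrogen on an aromatic carbon gives a 15-fold higher number from compound 3 to compound 4 (1.17 log units; beyond the scatter), and bromo in place of methyl on an aromatic carbon gives a 13-fold higher number from compound 2 to compound 4 (1.11 log units; beyond the scatter). The trifluoromethyl change lowers the number on the core of compound 1 but raises it on the core of compound 3, so its direction reverses between the two cores: the same change on two cores in this assay, a 3.6-fold lower number (0.55 log units; beyond the scatter) from compound 1 to compound 2 and a 15-fold higher number (1.17 log units; beyond the scatter) from compound 3 to compound 4, 52-fold (1.72 log units) apart, beyond the scatter of two such steps The bromo change reverses in the same way, which shows that neither change can be carried as a fixed step within these four compounds, though it does not show what underlies the reversal or whether compound 4 is a lone exception: the same change on two cores in this assay, a 4.0-fold lower number (0.60 log units; beyond the scatter) from compound 1 to compound 3 and a 13-fold higher number (1.11 log units; beyond the scatter) from compound 2 to compound 4, 52-fold (1.72 log units) apart, beyond the scatter of two such steps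

As far as these compounds go, it remains open whether a chloro or methoxy group in place of the trifluoromethyl on the core of compound 3 would also raise the number, or whether the rise is confined to trifluoromethyl and bromo occurring together. From the compounds shown here alone, it also remains open whether a chloro group in place of the bromo on the core of compound 2 would give a number near that of compound 2 or near that of compound 4.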